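The source may report more compounds than this note shows. Statements on the series, on what has been measured and on what is new or still open speak of the compounds shown alone.

Compound 1 `O=C(Nc1cccc(CNc2nccnc2Cl)c1)NC1CCCCC1`: > 40000 nM
Compound 2 `Cc1ccc(NC(=O)Nc2cccc(CNc3nccnc3Cl)c2)c(C)c1`: 9290 nM

In a functional assay on HepG2 cells (Homo sapiens) for antiproliferative activity, read by MTT assay, with a stated time of 48 h (on this read-out higher numbers stand for weaker inhibition and lower numbers for stronger inhibition), compound 1 gives only a limit, > 40000 nM, and that result sits at the limit of > 40000 nM in this assay, at which 1 of the 2 values shown sits. Within the data shown here, compound 2 gives 9290 nM in this assay, the only actual number among the two values shown. Among the measured compounds shown here, the one measured step, an at least 4.3-fold lower number from compound 1 to compound 2 (0.63 log units; beyond the scatter), came with 2,4-dimethylphenyl in place of cyclohexyl on an amide-type nitrogen. Compound 3 `Cc1ccccc1NC(=O)Nc1cccc(CNc2nccnc2Cl)c1` keeps the core of compound 2 and differs from it in one spot: hydrogen in place of methyl on an aromatic carbon, which reads 2,4-dimethylphenyl to 2-methylphenyl. For the measured compounds named here, no measured step removes a single methyl from that ring, so the step from compound 1 to compound 2 gives only indirect guidance: the aromatic replacement brought the lower number, but nothing shows how much the second methyl contributes to it. A change of at most modest size is expected, if anything toward a higher number, so for compound 3 the expected step is a 1.3-fold higher number from compound 2 to compound 3 (0.11 log units; within the scatter). Compound 3 is estimated at 12000 nM, within 5000 nM to 30000 nM in this assay.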

Compound 3, half-maximal inhibitory concentration: 15300 nM
The estimate for compound 3 lay 1.3-fold (0.11 log units) below the measured number, within the range that was stated.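

In this assay, hydrogen in place of the methyl para to a large group gives a 1.6-fold higher number from compound 2 to compound 3 (0.22 log units; within the scatter), so compound 2 and compound 3 cannot be told apart and this methyl is not shown to matter. The 2-methylphenyl group still gives an at least 2.6-fold lower number from compound 1 to compound 3 (0.41 log units; beyond the scatter), so the change from cyclohexyl to an aromatic ring keeps its effect with this methyl gone. The true size of that step is unknown, as the number for compound 1 is only a limit: the limit of > 40000 nM in this assay, at which 1 of the 3 values shown sits.

The compounds shown do not tell whether a plain phenyl ring, with the remaining methyl gone too, would hold the number reached by compound 3. They also leave open whether chlorine or methoxy in place of the removed methyl would shift the number beyond the scatter.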